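Working notes: amine swap from compound 2 to compound 3

The compounds below may be only part of what the source reports. "The series", "measured", "known", "first", "only" and "open" are said of these compounds alone.

Measured in a functional assay on MIA PaCa-2 cells (Homo sapiens) for cytotoxicity, read by fluorescence, with a stated time of 48 h; on this read-out lower numbers stand for an effect already at smaller amounts and higher numbers for an effect only at larger amounts of compound:
compound 1 `CC(C)=CCC/C(C)=C/CC/C(C)=C/CSC[C@H](NC(=O)CCCCCN1CCN(C)CC1)C(=O)N1CCCC1` gives 6000 nM
compound 2 `CC(C)=CCC/C(C)=C/CC/C(C)=C/CSC[C@H](NC(=O)CCCCCN1CCCC1)C(=O)N1CCCCC1` gives 12400 nM

Of these two numbers, compound 2 holds the higher (12400 nM). Compound 1 sits lower (6000 nM), and the gap lies beyond the usual scatter. The two compounds differ in more than one place, so the gap cannot be assigned to any single change.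

The next compound is compound 3 `CC(C)=CCC/C(C)=C/CC/C(C)=C/CSC[C@H](NC(=O)CCCCCN1CCN(C)CC1)C(=O)N1CCCCC1`, not yet measured. It departs from compound 2 in one place: 4-methylpiperazin-1-yl in place of pyrrolidin-1-yl on a saturated chain carbon, five bonds along the chain from a carbonyl carbon on a saturated chain carbon, five bonds along the chain from a carbonyl carbon.

Going by the values given here, no step at a single place has been measured in this assay for comparison. Among the compounds with values here, the only hint is that compound 1 also carries 4-methylpiperazin-1-yl and has the lower number (6000 nM), though its second difference blurs that reading. A modest move toward lower numbers is expected, possibly none beyond the scatter. The estimate means a 1.6-fold lower number from compound 2 to compound 3 (0.19 log units; within the scatter) as the expected change. The estimated value for compound 3 is 8000 nM (expected range 3500 nM to 17000 nM).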

Compound 3, half-maximal effective concentration: 14300 nM
Estimate against measurement, compound 3: 1.8-fold (0.25 log units) below; the measured number falls inside the stated range.
By their numbers in this assay, from the lowest: compound 1; then compounds 2 and 3 (each within the scatter of the next).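

In this assay, 4-methylpiperazin-1-yl in place of pyrrolidin-1-yl on a saturated chain carbon, five bonds along the chain from a carbonyl carbon, gives a 1.2-fold higher number from compound 2 to compound 3 (0.06 log units; within the scatter), so with piperidin-1-yl on the carbonyl carbon, this exchange of chain-end amines leaves no difference that can be told from the scatter. Compound 3 also gives a single-place reading on the carbonyl carbon: with 4-methylpiperazin-1-yl held on the chain, piperidin-1-yl in place of pyrrolidin-1-yl gives a 2.4-fold higher number from compound 1 to compound 3 (0.38 log units; beyond the scatter), a modest step and the only one of the two that lies beyond the scatter. Nothing at hand gives a reason for either step.

Going by these compounds alone, it remains open whether the chain-end exchange would stay as flat with pyrrolidin-1-yl on the carbonyl carbon, since the one reading so far carries piperidin-1-yl there. Going by these compounds, it is also open how a morpholin-4-yl or dimethylamino group at the chain end, or a morpholin-4-yl group on the carbonyl carbon, would read in this assay.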